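This account rests on a few compounds, and the source may have more. Where it says the series, first, only, none or still open, it means among the compounds named here.

Working notes on the thiadiazine-fused series. All three measured members carry the same core and differ only at the aryl groups; they have been run in a functional assay on MCF7 cells (Homo sapiens) for inhibition, read by sulforhodamine B assay, with a stated time of 72 h; a lower number here means a stronger inhibitor, a higher number a weaker inhibitor. Compound 1 `CC(c1ccc(-c2ccccc2)c(F)c1)c1nnc2n1N=C(c1ccc(Cl)cc1)CS2` gives 8700 nM. Compound 2 `COc1ccc2cc(C(C)c3nnc4n3N=C(c3ccc(C)cc3)CS4)ccc2c1` gives 11000 nM in this assay, and compound 3 `CC(C)Cc1ccc(C(C)c2nnc3n2N=C(c2ccc(F)cc2)CS3)cc1` gives 8900 nM. Among the compounds with values here, compound 1 thus holds the smallest of the three numbers, but its gaps to compound 3 and to compound 2 both fall inside the scatter of repeated measurements, so the three compounds read as one cluster rather than a ranking, and no single compound can be called the more potent.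

The next member to be measured is compound 4 `CC(c1ccc(-c2ccccc2)c(F)c1)c1nnc2n1N=C(c1ccc([N+](=O)[O-])cc1)CS2`. It keeps the fluorinated biphenyl side of compound 1 and changes only the other aryl group: nitro in place of chloro on an aromatic carbon. Within the data shown here, no measured pair shows what a nitro in place of chloro at this position does, so there is nothing in the data to anchor the size or direction of the step. Given the flat cluster of numbers seen so far, the change is expected to leave the value close to that of compound 1. The step of a 1.0-fold higher number from compound 1 to compound 4 (0.01 log units; within the scatter) is expected to stay within the scatter. Compound 4 is therefore estimated at 9000 nM in this assay, with a range from 4000 nM to 20000 nM.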

Compound 4, half-maximal inhibitory concentration: 7800 nM
Compound 4: middle estimate off by 1.2-fold (0.06 log units), on the high side; the measured number falls inside the stated range.
By their numbers in this assay, from the lowest: compounds 4, 1, 3 and 2 (each within the scatter of the next).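

Within the data shown here, this is the first pair that differs in one place, so the change of 4-chlorophenyl to 4-nitrophenyl can now be read directly: in this assay there is a 1.1-fold lower number from compound 1 to compound 4 (0.05 log units; within the scatter), and the two compounds cannot be told apart. With the fluorinated biphenyl side held fixed, this aromatic carbon, para to a large group, thus carries either chloro, with one heavy atom and no hydrogen-bond acceptors, or nitro, with three heavy atoms and two hydrogen-bond acceptors, and the step stays within the scatter. No measurement at hand bears on why the two compounds read alike.

This single pair leaves open whether an amine or a carboxylic acid on the same aromatic carbon would also stay within the scatter of compound 1. It also leaves open whether nitro in place of chloro would give a comparably small step with the other side of compound 2 or compound 3, since neither of those compounds yet has a partner that differs from it in one place.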